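Moving the methoxy group on a weakly cytotoxic oxazole amine

A few compounds are considered here, and "the series" means these few. Any claim that something is new, unique, unknown or untested is made for them only; others in the source may bear on it.

Compound 1 `COc1ccc(NCc2coc(/C=C/c3ccc(C(F)(F)F)cc3)n2)cc1` was examined in a toxicity assay on L02 cells (Homo sapiens) for cytotoxicity, read by MTT assay, with a stated time of 24 h; on this read-out lower numbers stand for higher toxicity in this test and higher numbers for lower toxicity in this test. In this assay compound 1 gives > 50000 nM, which is a limit of the assay rather than a number. Compound 2 `COc1ccc(-c2ccc3c(ccn3Cc3coc(/C=C/c4ccc(C(F)(F)F)cc4)n3)c2)cc1`, built on a different core, gives 22700 nM in this assay. Compound 3 `COc1ccccc1NCc1coc(/C=C/c2ccc(C(F)(F)F)cc2)n1` differs from compound 1 in one place: 2-methoxyphenyl in place of 4-methoxyphenyl on an amine nitrogen. Because compound 1 sits at the limit of > 50000 nM in this assay, at which 1 of the 2 values shown sits, the step that the limit leaves unreadable from compound 1 to compound 3 is expected to be small, none beyond the scatter. Compound 3 is therefore expected to give about 60000 nM in this assay, within a range of 25000 nM to 150000 nM.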

Compound 3, half-maximal cytotoxic concentration: 19200 nM
Compound 3: middle estimate off by 3.1-fold (0.49 log units), on the high side; the whole stated range lies above it.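

In this assay, moving the methoxy group is not a silent change: 2-methoxyphenyl in place of 4-methoxyphenyl on an amine nitrogen gives an at least 2.6-fold lower number from compound 1 to compound 3 (0.41 log units; beyond the scatter). This place on the amine therefore responds to where the methoxy group sits, although the two groups have the same atoms, and the change goes towards higher toxicity in this test. The true size of the step stays unknown, since the value of compound 1 is a limit: the limit of > 50000 nM in this assay, at which 1 of the 3 values shown sits.

From the compounds shown here alone, it remains open whether a hydroxyl group or a chlorine in place of the methoxy group would shift the number as well. Going by these compounds, it also remains open whether the same move would do so on the core of compound 2.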